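A Chloro Substituent on the Phenyl Ring of Compound 1

A few compounds are considered here, and "the series" means these few. Any claim that something is new, unique, unknown or untested is made for them only; others in the source may bear on it.

Compound 1 `COc1cc(/C=C/C(=O)c2cccc(-n3cc(-c4ccccc4)[nH]c3=O)c2)ccc1O` was measured in a functional assay on SK-MEL-5 cells (Homo sapiens) for inhibition (on this read-out lower numbers stand for stronger inhibition of growth and higher numbers for weaker inhibition of growth), where compound 1 gives 1590 nM. Two companions share its core. Compound 2 `COc1ccc(-c2cn(-c3cccc(C(=O)/C=C/c4cc(OC)c(OC)c(OC)c4)c3)c(=O)[nH]2)cc1` gives 2030 nM, and compound 3 `COc1cc(/C=C/C(=O)c2cccc(-n3cc(-c4cc(OC)c(OC)c(OC)c4)[nH]c3=O)c2)cc(OC)c1OC` gives 2760 nM. Compound 1 has the lowest of the three numbers, yet its gaps to compound 2 and to compound 3 both lie within the usual scatter of repeated measurements, so no order among the three can be read from these values.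

Among the measured compounds shown here, only one measured pair differs in a single place: a 1.4-fold higher number from compound 2 to compound 3 (0.13 log units; within the scatter). That step changed the substituents on the phenyl ring attached to the core and left the read-out essentially where it was.

Compound 4 `COc1cc(/C=C/C(=O)c2cccc(-n3cc(-c4ccc(Cl)cc4)[nH]c3=O)c2)ccc1O` has not yet been measured. It differs from compound 1 by chloro in place of hydrogen on an aromatic carbon, the chlorine entering on an aromatic carbon of a six-membered aromatic ring of carbon only, para to a large group, on the same ring that was varied between compound 2 and compound 3. Because that earlier exchange gave a 1.4-fold higher number from compound 2 to compound 3 (0.13 log units; within the scatter), a similarly small effect is expected here, with no shift beyond the scatter in either direction. Compound 4 is therefore estimated at 1500 nM, with a range from 700 nM to 3500 nM. This estimate means a 1.1-fold lower number from compound 1 to compound 4 (0.03 log units; within the scatter), a step expected to remain within the scatter.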

Compound 4, concentration for 50% growth inhibition: 1800 nM
The estimate for compound 4 lay 1.2-fold (0.08 log units) below the measured number; the measured number falls inside the stated range.
By their numbers in this assay, from the lowest: compounds 1, 4, 2 and 3 (each within the scatter of the next).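

In this assay, chloro in place of hydrogen on an aromatic carbon, para to a large group, gives a 1.1-fold higher number from compound 1 to compound 4 (0.05 log units; within the scatter), so compound 1 and compound 4 cannot be told apart on this read-out. Among the compounds shown here, the only earlier step on this ring, a 1.4-fold higher number from compound 2 to compound 3 (0.13 log units; within the scatter), exchanged 4-methoxyphenyl for 3,4,5-trimethoxyphenyl, so it started from a ring that already carried a substituent, whereas the new step starts from the plain phenyl and adds a single chlorine, a halogen rather than a methoxy group. Together, the two steps show that neither exchange on this ring moves the number beyond the scatter, although the new result covers only this one atom at this one place, and no measurement here offers an explanation for it.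

Going by these compounds, whether an amine or a carboxylic acid at this same place would stay within the scatter of compound 1 or move beyond it remains open. On these data alone, it is also open whether a longer chain would behave as chloro does, and whether chloro would give the same result on the shared core with the other end of compound 2 in place of that of compound 1.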